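Triazole series: fluoro in place of trifluoromethoxy

The source may report more compounds than this note shows. Statements on the series, on what has been measured and on what is new or still open speak of the compounds shown alone.

Measured so far:
compound 1 `CCOC(=O)c1cn(C(c2ccccc2)c2cc3cc(Br)ccc3nc2OC)nn1`: 2%
compound 2 `COc1nc2ccc(Br)cc2cc1C(c1ccccc1)n1cc(-c2ccc(OC(F)(F)F)cc2)nn1`: 5.8%

In an ADME assay on HEK293 cells (Homo sapiens) for cytotoxicity, read by sulforhodamine B assay, with a stated time of 48 h, tested at 10 uM (on this read-out higher numbers stand for more inhibition at the one concentration tested (going by the name of the read-out) and lower numbers for less inhibition), compound 1 gives 2%, and compound 2 gives 5.8%. Going by the values given here, the only measured step, a number 3.8 percentage points higher from compound 1 to compound 2 (within the scatter), is within the scatter, so the two numbers are not distinguishable. Compound 2 holds the higher of the two numbers on paper, but that standing means nothing beyond the scatter.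

Compound 3 `COc1nc2ccc(Br)cc2cc1C(c1ccccc1)n1cc(-c2ccc(F)cc2)nn1` differs from compound 2 by fluoro in place of trifluoromethoxy on an aromatic carbon. Among the compounds with values here, no measured step bears directly on this change; the one step on record concerns a different group at the same aromatic carbon and was itself within the scatter. Both measured compounds sit low in this assay, with nothing to suggest a shift for compound 3. The step of a number 1.8 percentage points lower from compound 2 to compound 3 (within the scatter) is therefore expected to lie within the scatter. Compound 3 is estimated at 4%, with a range from -6% to 14%.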

Compound 3, a percentage reported as inhibition, at one concentration (the size of the read-out at that concentration, not a potency): 4.04%
Estimate against measurement, compound 3: 0 percentage points below; low and high end bracket the measured number.
By their numbers in this assay, from the lowest: compounds 1, 3 and 2 (each within the scatter of the next).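

In this assay, going from trifluoromethoxy to fluoro on the aromatic carbon para to a large group, a change from 5 heavy atoms to 1, gives a number 1.8 percentage points lower from compound 2 to compound 3 (within the scatter), so the size of this substituent on the phenyl ring has no readable effect here. Replacing ethoxycarbonyl with 4-fluorophenyl gives a number 2 percentage points higher from compound 1 to compound 3 (within the scatter), so this second aryl group, like 4-(trifluoromethoxy)phenyl, cannot be told apart from the ester at this position. No supporting data bear on why these numbers stay together.

The compounds shown leave open whether any group at this position can move the read-out beyond the scatter, for example a carboxylic acid or a dimethylamino group on the phenyl ring, or a longer alkyl chain in its place. They also leave open what changes at the bromo or methoxy groups of the shared core would do.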